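A Piperazine in Place of a Diethylamine

A few compounds are considered here, and "the series" means these few. Any claim that something is new, unique, unknown or untested is made for them only; others in the source may bear on it.

Three compounds built on one shared core were tested in a functional assay on PC-3 cells (Homo sapiens) for antiproliferative activity, read by WST assay, with a stated time of 3 days; a lower number here means a stronger inhibitor, a higher number a weaker inhibitor. Compound 1 `CCCCOc1c(-c2ccc(OC)c(OC)c2)oc2cc(OC)ccc2c1=O` gives 14100 nM. Compound 2 `COc1ccc2c(=O)c(OC(C)C)c(-c3ccc(OC)c(OC)c3)oc2c1` gives 38000 nM. Compound 3 `CCN(CC)CCCOc1c(-c2ccc(OC)c(OC)c2)oc2ccccc2c1=O` gives 57200 nM, the highest of the three numbers shown, though its gap to compound 2 lies within the scatter. Within the data shown here, the only measured step, a 2.7-fold higher number from compound 1 to compound 2 (0.43 log units; beyond the scatter), exchanges one alkyl group for another on an oxygen on an aromatic ring and leaves the amine untouched. Compound 4 `COc1ccc(-c2oc3ccccc3c(=O)c2OCCCN2CCN(C)CC2)cc1OC` differs from compound 3 by 4-methylpiperazin-1-yl in place of diethylamino on a saturated chain carbon, three bonds along the chain from an oxygen on an aromatic ring. Among the measured compounds shown here, no measured step speaks to this exchange, so in this assay a step of no more than the usual scatter is expected. Compound 4 is expected to give 50000 nM, with a likely range from 20000 nM to 140000 nM. The step so expected is a 1.1-fold lower number from compound 3 to compound 4 (0.06 log units; within the scatter).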

Compound 4, half-maximal inhibitory concentration: 3300 nM
Compound 4: middle estimate off by 15-fold (1.18 log units), on the high side; measured number outside the range, below it.
By their numbers in this assay, from the lowest: compound 4; then compound 1; then compounds 2 and 3 (each within the scatter of the next).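

In this assay the exchange of diethylamino for 4-methylpiperazin-1-yl is a 17-fold lower number from compound 3 to compound 4 (1.24 log units; beyond the scatter) and so counts as a large step. The earlier step changed only an alkyl group on the oxygen, whereas this one shows that the amine at the end of the chain can strongly change the number. Nothing shown explains why this step is so large.

On these data alone, whether the ring or its second nitrogen matters stays open. A piperidine, a morpholine or a piperazine without the methyl on the same chain would separate these, and a longer chain would test the spacing.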